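The compounds below may be only part of what the source reports. "The series", "measured", "known", "first", "only" and "open" are said of these compounds alone.

Compound 1 `COc1ccc(-c2cn3ccnc3c(-c3ccc4ncn(C5CCCCC5)c4c3)n2)cc1` stands highest of the three compounds measured in a functional assay on NCI-H23 cells (Homo sapiens) for inhibition, read by sulforhodamine B assay, with a stated time of 48 h, tested at 10 uM (on this read-out lower numbers stand for less inhibition and higher numbers for more inhibition at the one concentration tested (going by the name of the read-out)), where compound 1 gives 62.2%. Compound 2 `c1cn2cc(-c3ccsc3)nc(-c3ccc4ncn(C5CCCCC5)c4c3)c2n1` gives 10%, and compound 3 `CC(=O)c1ccc(-c2cn3ccnc3c(-c3ccc4ncn(C5CCCCC5)c4c3)n2)cc1` gives 8.6%, both far beneath it. The change to compound 4 `Clc1ccc(-c2cn3ccnc3c(-c3ccc4ncn(C5CCCCC5)c4c3)n2)cc1` is chloro in place of methoxy on an aromatic carbon. The most telling measured step alters the same methoxy group: a number 53.6 percentage points lower from compound 1 to compound 3 (beyond the scatter). The other step away from compound 1, a number 52.2 percentage points lower from compound 1 to compound 2 (beyond the scatter), swaps the whole ring instead, yet also fell steeply. Going by the values given here, with only two large downward steps from compound 1 to go on, and no other replacement of methoxy measured, a loss beyond the scatter is expected, though one smaller than the acetyl case remains plausible. Compound 4 is estimated at 30%, within 5% to 60%, an expected step of a number 32.2 percentage points lower from compound 1 to compound 4 (beyond the scatter).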

Compound 4, a percentage reported as inhibition, at one concentration (the size of the read-out at that concentration, not a potency): 4.11%
Beside the measured number, compound 4's estimate is 25.9 percentage points above it; measured number outside the range, below it.
By their numbers in this assay, from the lowest: compounds 4, 3 and 2 (each within the scatter of the next); then compound 1.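

Replacing methoxy with chloro at this position gives a large loss in this assay (a number 58.1 percentage points lower from compound 1 to compound 4 (beyond the scatter)), so this is a second replacement of methoxy on this ring that does not keep the inhibition. Chloro also sits level with the other low compounds (a number 4.5 percentage points lower from compound 3 to compound 4 (within the scatter); a number 5.9 percentage points lower from compound 2 to compound 4 (within the scatter)), and among these four compounds only the 4-methoxyphenyl compound stands high. No measurement here explains this loss. From the compounds shown here alone, whether ethoxy, hydroxyl or an amine at this position would keep the inhibition remains open.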